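The source may report more compounds than this note shows. Statements on the series, on what has been measured and on what is new or still open speak of the compounds shown alone.

Compound 2 `OC(CCn1nc2c(Br)c(Br)c(Br)c(Br)c2n1)c1ccc(Br)cc1` shows no measurable effect in a functional assay on CCRF-CEM cells (Homo sapiens) for antiproliferative activity, read by MTT assay, with a stated time of 24 h, tested at 100 uM; on this read-out lower numbers stand for a stronger effect and higher numbers for a weaker effect at the one concentration tested: compound 2 gives 0%. Compound 1 `OC(CCn1nc2c(Br)c(Br)c(Br)c(Br)c2n1)c1cccc(Br)c1` gives 0%, and the step of no change at the digits printed from compound 1 to compound 2 (within the scatter) stays within the scatter. Compound 3 `OC(CCn1nc2c(Br)c(Br)c(Br)c(Br)c2n1)c1ccc(Cl)cc1` differs from compound 2 by chloro in place of bromo on an aromatic carbon. Within the data shown here, no measured step exchanges one halogen for another, so the only guidance is that moving the bromine around the ring left the read-out unchanged. The expected step is no change at the digits printed from compound 2 to compound 3 (within the scatter), nothing beyond the scatter. Compound 3 is therefore estimated at 0%, with a range of 0% to 10%.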

Compound 3, a percentage reported as activity, at one concentration (the size of the read-out at that concentration, not a potency): 0%
For compound 3 middle estimate and measured number coincide at the digits printed, within the range that was stated.
By their numbers in this assay, from the lowest: compounds 1, 2 and 3 (each within the scatter of the next).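

Swapping the halogen itself, 4-bromophenyl to 4-chlorophenyl, reads no change at the digits printed from compound 2 to compound 3 (within the scatter) in this assay and is the first halogen exchange here. Changing the halogen and its ring position together reads no change at the digits printed from compound 1 to compound 3 (within the scatter) on the same read-out, so chloro and bromo cannot be told apart at this position. No measured evidence accounts for this result.

On these data alone, an amine or a carboxylic acid on the ring in place of the halogen remains open. So does a longer chain between the ring and the shared core.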